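A few compounds are considered here, and "the series" means these few. Any claim that something is new, unique, unknown or untested is made for them only; others in the source may bear on it.

Measured compounds:
- compound 1, `COc1c(N2CCCC2)c(F)cc2c(=O)c(C(=O)O)cn(C3CC3)c12`, in a functional assay on V79 cells (Cricetulus griseus) for cytotoxicity, read by colony formation (on this read-out lower numbers stand for stronger inhibition and higher numbers for weaker inhibition), compound 1 gives 150 ug/mL.
- compound 2, `O=C(O)c1cn(C2CC2)c2c(C(F)(F)F)c(N3CCCC3)c(F)cc2c1=O`, compound 2 gives 280 ug/mL.
- compound 3, `COc1c(N2CCC(C)(CN)C2)c(F)cc2c(=O)c(C(=O)O)cn(C3CC3)c12`, compound 3 gives 38 ug/mL.

Compound 4, `CC1(CN)CCN(c2c(F)cc3c(=O)c(C(=O)O)cn(C4CC4)c3c2C(F)(F)F)C1`, has not yet been measured. It differs from compound 3 by trifluoromethyl in place of methoxy on an aromatic carbon. The same kind of change separates compound 1 from compound 2: trifluoromethyl in place of methoxy on an aromatic carbon. The two places are not identical: in compound 1 the position is ortho to a pyrrolidin-1-yl group, while in compound 3 it is ortho to a 3-(aminomethyl)-3-methylpyrrolidin-1-yl group. The cores differ by 3-(aminomethyl)-3-methylpyrrolidin-1-yl in place of pyrrolidin-1-yl on an aromatic carbon, a change that gave a 3.9-fold lower number from compound 1 to compound 3 (0.60 log units; beyond the scatter).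

The measured step of this kind, a 1.9-fold higher number from compound 1 to compound 2 (0.27 log units; within the scatter), is small. For compound 4 a step of similar size is expected, a 1.8-fold higher number from compound 3 to compound 4 (0.27 log units; within the scatter), resting on the result for compound 2 of 280 ug/mL against compound 1. Compound 4 is therefore estimated at 70 ug/mL, in a range from 30 ug/mL to 160 ug/mL.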

Compound 4, half-maximal inhibitory concentration: 110 ug/mL
Beside the measured number, compound 4's estimate is 1.6-fold (0.20 log units) below it; measured number inside the range.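

In this assay, trifluoromethyl in place of methoxy gives a 2.9-fold higher number from compound 3 to compound 4 (0.46 log units; beyond the scatter), and this step agrees with the one seen on the core of compound 1: the same change on two cores in this assay, a 1.9-fold higher number (0.27 log units; within the scatter) from compound 1 to compound 2 and a 2.9-fold higher number (0.46 log units; beyond the scatter) from compound 3 to compound 4, 1.6-fold (0.19 log units) apart, within the scatter of two such steps. Likewise, 3-(aminomethyl)-3-methylpyrrolidin-1-yl in place of pyrrolidin-1-yl gives a 2.5-fold lower number from compound 2 to compound 4 (0.41 log units; beyond the scatter), which agrees with its earlier step: the same change on two cores in this assay, a 3.9-fold lower number (0.60 log units; beyond the scatter) from compound 1 to compound 3 and a 2.5-fold lower number (0.41 log units; beyond the scatter) from compound 2 to compound 4, 1.6-fold (0.19 log units) apart, within the scatter of two such steps. Each change therefore carried over between these two cores in the same direction and by a similar amount, so here the effect of one change did not visibly depend on the other, but these four compounds in a single assay cannot show why, or whether this would hold on a third core.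

The compounds shown leave open how other groups in place of methoxy, such as a chlorine atom, an ethoxy group or a hydrogen, would behave. They also leave open whether a different amine, such as piperazin-1-yl, would give a similar step from pyrrolidin-1-yl.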